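The source may report more compounds than this note shows. Statements on the series, on what has been measured and on what is new or still open speak of the compounds shown alone.

Measured in an assay on HEK293 cells for displacement of a labelled ligand from C-X-C chemokine receptor type 3 (Homo sapiens); a lower number here means a stronger inhibitor, a higher number a weaker inhibitor:
compound 1 `CN(CC1=CC[C@H]2C[C@@H]1C2(C)C)Cc1ccc(F)cc1` gives 6310 nM
compound 2 `CN(CC1=CC[C@H]2C[C@@H]1C2(C)C)Cc1ccc(Cl)cc1` gives 2510 nM
compound 3 `CN(CC1=CC[C@H]2C[C@@H]1C2(C)C)Cc1ccc(Cl)c(Cl)c1` gives 3160 nM

Compound 2 gives the lowest of these three numbers, though compound 3 lies within the scatter of it, and compound 1 is the furthest away. Two steps describe the set: a 2.5-fold lower number from compound 1 to compound 2 (0.40 log units; beyond the scatter), and a 1.3-fold higher number from compound 2 to compound 3 (0.10 log units; within the scatter). Compound 4 `CN(CC1=CC[C@H]2C[C@@H]1C2(C)C)Cc1ccc(-c2ccccc2F)cc1` has not been measured; relative to compound 2 the change is 2-fluorophenyl in place of chloro on an aromatic carbon. Neither measured step involves a group of this kind: the first exchanges one halogen for another, the second adds a halogen, whereas the 2-fluorophenyl brings in a whole six-membered aromatic ring of carbon only. The exchange of fluoro for chloro shows that a change at the same aromatic carbon can move this assay beyond the scatter, while the added chloro in compound 3 shows that not every change there does. Among the compounds with values here, with no closer precedent, a step of modest size at most is expected, its direction uncertain but leaning toward a lower number, and the estimated step is a 1.6-fold lower number from compound 2 to compound 4 (0.20 log units; within the scatter). Compound 4 is therefore expected to give about 1600 nM in this assay, within a range from 400 nM to 6300 nM.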

Compound 4, inhibition constant: > 316 nM
Compound 4: a limit, no number (the forecaster's own chance of this, stated with the estimate: 10%); the middle value is on the limit's open side.
By their numbers in this assay, from the lowest: compounds 2, 3 and 1 (each within the scatter of the next, the first and the last beyond it).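

In this assay compound 4 gives > 316 nM, which is a limit and not a number. The steps from compound 2 and from compound 1 to compound 4 therefore cannot be read. The compounds shown leave open whether 2-fluorophenyl in place of chloro gives a lower or a higher number than compound 2 in this assay.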